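The source may hold more compounds than are shown below. What is called first, only, known or untested is meant among the compounds shown, and "the series" means these compounds.

Working notes on the series. Compound 1 `Cc1ccc(-c2cnc(C)n2C)cc1NC(=O)c1ccc(OCc2ccccn2)cc1` in a physicochemical assay for solubility, at pH 7.4 (a higher number here means a more soluble compound, a lower number a less soluble compound), gives 371000 nM. For compound 2 `Cc1cc(C)c(-c2nc3ccccc3[nH]2)cc1NC(=O)c1ccc(OCc2ccccn2)cc1` the picture is different: in this assay compound 2 gives < 1000 nM, which is a limit of the assay and not a number (the limit of < 1000 nM in this assay, at which 1 of the 2 values shown sits). Going by the values given here, compound 2 thus sits at the limit end of the numbers seen so far and has no figure of its own, so no step between measured compounds can be drawn. Compound 3 `Cc1cc(C)c(-c2cccnc2)cc1NC(=O)c1ccc(OCc2ccccn2)cc1` differs from compound 2 in one place: pyridin-3-yl in place of 1H-benzimidazol-2-yl on an aromatic carbon. Among the compounds with values here, no measured pair shows the effect of this change, so the expected size of the step rests on the structures alone. An upward step in this assay beyond the usual scatter is expected, of about an at least 40-fold higher number from compound 2 to compound 3 (1.60 log units; beyond the scatter). Compound 3 is estimated in this assay at 40000 nM, with a range of 4000 nM to 300000 nM.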

Compound 3, solubility: 9000 nM
For compound 3 the middle estimate is 4.4-fold (0.65 log units) above the measured one; measured number inside the range.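

Going by these compounds alone, replacing 1H-benzimidazol-2-yl with pyridin-3-yl on this aromatic carbon, ortho to a methyl group and para to a methyl group, gives the first readable step at this position in this assay: an at least 9.0-fold higher number from compound 2 to compound 3 (0.95 log units; beyond the scatter). Going by these compounds, compound 2 gives < 1000 nM, which is a limit of the assay and not a number, so the step is a floor and its full size stays unknown: the limit of < 1000 nM in this assay, at which 1 of the 3 values shown sits. The change swaps a two-ring group carrying a hydrogen-bond donor for a single ring with none, and compound 3 gives the first actual figure at this position.

A single pair cannot separate the loss of the donor from the loss of the carbon ring. On these data alone, how an amine or a carboxylic acid on this aromatic carbon would read in this assay remains open.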